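Triazole series: fluorophenyl in place of methoxyphenyl

This account rests on a few compounds, and the source may have more. Where it says the series, first, only, none or still open, it means among the compounds named here.

Two compounds of this series carry a measurement. Compound 1 `COc1ccc(-n2ncnc2-c2cc(OC)c(OC)c(OC)c2)cc1` is tested in a functional assay on Jurkat cells (Homo sapiens) for antiproliferative activity, read by MTT assay, with a stated time of 72 h (on this read-out higher numbers stand for weaker inhibition and lower numbers for stronger inhibition), where compound 1 gives 93 nM. Among the compounds with values here, compound 2 `COc1cc(-n2ncnc2-c2ccc(SC)cc2)cc(OC)c1OC` is the only other measured member; in this assay compound 2 gives 50 nM. The two numbers lie within the usual scatter of each other, so compound 1 stands level with compound 2 on what has been measured, and nothing separates them.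

Within the data shown here, compound 3 `COc1cc(-c2ncnn2-c2cccc(F)c2)cc(OC)c1OC` has no measurement yet. Its structure differs from that of compound 1 in one place: 3-fluorophenyl in place of 4-methoxyphenyl on an aromatic nitrogen. The group that leaves carries the one hydrogen-bond acceptor of that ring; the group that enters carries none. Among the measured compounds shown here, no pair of measured compounds shows what such a change does on this core, so the step has to be guessed from the structural change alone.

For compound 3 a weaker inhibition than compound 1 is expected, with an estimated step of a 4.3-fold higher number from compound 1 to compound 3 (0.63 log units; beyond the scatter). The value of compound 3 in this assay is estimated at 400 nM, in a range from 100 nM to 2000 nM.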

Compound 3, half-maximal inhibitory concentration: > 10000 nM
Compound 3 was reported as a limit (the forecaster's own chance of this, stated with the estimate: 5%); middle value at least 25-fold (1.39 log units) from the limit.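

In this assay, exchanging 4-methoxyphenyl for 3-fluorophenyl on the aromatic nitrogen gives an at least 100-fold higher number from compound 1 to compound 3 (2.03 log units; beyond the scatter). Compound 3 is reported only as a limit and not as a number: the limit of > 10000 nM in this assay, at which 1 of the 3 values shown sits. The earlier compounds shown here offered no single-place step on this core, whereas this one shows that the group on the aromatic nitrogen cannot be exchanged freely: a six-membered aromatic ring of carbon only stays there in both compounds, yet the step lies beyond the scatter.

The change replaces the substituent and moves its place on the ring in one step, so the compounds shown cannot separate the loss of the methoxy group from the arrival of fluorine or from the new ring place. Also open, from the compounds shown here alone, is how a plain phenyl, or a phenyl carrying a hydroxyl or an amine, would behave on the aromatic nitrogen, and whether the result with 3-fluorophenyl carries over to the core of compound 2, which has a different pair of aryl groups.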